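The source may report more compounds than this note shows. Statements on the series, on what has been measured and on what is new or still open speak of the compounds shown alone.

Measured compounds:
compound 1, `Cc1ccccc1-c1nc(CN2CCC(C(=O)NCCCN3CCC(C(C)C)CC3)CC2)c(C)o1`, > 71 ug/mL;
compound 2, `Cc1ccccc1-c1nc(CN2CCC(C(=O)NCCCN3[C@H](C)CCC[C@@H]3C)CC2)c(C)o1`, > 69 ug/mL.

In a physicochemical assay for solubility, in phosphate buffer, measured as kinetic solubility, at pH 7.4 (on this read-out lower numbers stand for lower solubility and higher numbers for higher solubility), compound 1 gives > 71 ug/mL, which is a limit of the assay and not a number. In this assay compound 2 gives > 69 ug/mL, again a limit and not a number. The one measured step, a step that the two limits leave unreadable from compound 1 to compound 2, therefore cannot be read for size or direction; both values sit at limits, as shown by the limit of > 69 ug/mL in this assay, at which 1 of the 2 values shown sits, and (the limit of > 71 ug/mL in this assay, at which 1 of the 2 values shown sits). Compound 1 thus stands at a limit, with no numeric position on the scale.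

Compound 3 is `Cc1cccc(Cl)c1-c1nc(CN2CCC(C(=O)NCCCN3CCC(C(C)C)CC3)CC2)c(C)o1`. It differs from compound 1 by chloro in place of hydrogen on an aromatic carbon, with the rest of the shared core unchanged. For the measured compounds named here, no measured step touches this part of the molecule: the only step, from compound 1 to compound 2, concerns the chain end, and is unreadable besides. There is thus no measured basis for the size of the step to compound 3, and the expectation rests on compound 1 sitting at a limit.

The expected step is an at least 1.4-fold lower number from compound 1 to compound 3 (0.15 log units; that floor lies within the scatter). Compound 3 is estimated at 50 ug/mL, in the range 15 ug/mL to 100 ug/mL.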

Compound 3, solubility: > 76 ug/mL
Compound 3 was reported as a limit; the forecaster's own chance of this, stated with the estimate: 35%; middle value at least 1.5-fold (0.18 log units) from the limit.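

In this assay compound 3 gives > 76 ug/mL, a limit of the assay and not a number. Compound 1 also stands at a limit, so the step between compound 1 and compound 3 cannot be read for size or direction. The compounds shown leave open where any of the three falls on a numeric scale, and what chloro in place of hydrogen on an aromatic carbon does to the read-out.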